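From pyridin-4-yl to 2,4-dimethylphenyl in compound 3

The source may report more compounds than this note shows. Statements on the series, on what has been measured and on what is new or still open speak of the compounds shown alone.

Of the compounds shown here, three have so far been tested in an ADME assay on J774 cells (Mus musculus) for antiproliferative activity, with a stated time of 72 h; on this read-out lower numbers stand for an effect already at smaller amounts and higher numbers for an effect only at larger amounts of compound. Compound 1 `COC(=O)c1c[nH]c2cc(OC)c(Cl)cc2c1=O` gives 37000 nM. Compound 2 `CCc1c(C)[nH]c2cc(OCCOc3ccccc3)c(Cl)cc2c1=O` gives only a limit of the assay, > 28000 nM. Compound 3 `CCCCc1cc2c(=O)c(-c3ccncc3)c(C)[nH]c2cc1OCCOc1ccccc1` gives 23000 nM, and this number lies within the usual scatter of the number for compound 1, its nearest neighbour. So compound 3 cannot be separated from compound 1 on these data.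

The next compound changes one group. Compound 4 `CCCCc1cc2c(=O)c(-c3ccc(C)cc3C)c(C)[nH]c2cc1OCCOc1ccccc1` carries 2,4-dimethylphenyl in place of the pyridin-4-yl of compound 3, on an aromatic carbon (2,4-dimethylphenyl in place of pyridin-4-yl on an aromatic carbon). Going by the values given here, no two measured compounds differ in only one place, so no earlier step serves as a guide. The starting point is therefore compound 3 at 23000 nM, and no shift beyond the scatter is expected in this assay. The estimated change is a 1.2-fold lower number from compound 3 to compound 4 (0.06 log units; within the scatter). For compound 4 the expected value is 20000 nM, with an estimated range from 8000 nM to 45000 nM.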

Compound 4, half-maximal effective concentration: 22000 nM
For compound 4 the middle estimate is 1.1-fold (0.04 log units) below the measured one; the range from low to high includes it.
By their numbers in this assay, from the lowest: compounds 4, 3 and 1 (each within the scatter of the next).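

Going by these compounds alone, the swap of pyridin-4-yl for 2,4-dimethylphenyl gives the first comparison in this assay of two compounds that differ in one place: a 1.0-fold lower number from compound 3 to compound 4 (0.02 log units; within the scatter). On this aromatic carbon, then, a ring with a nitrogen can give way to a ring of carbon only, carrying two methyl groups, without a shift that stands out from the scatter in this assay. Compound 2 gives a limit, not a number, and so stays out of this comparison: the limit of > 28000 nM in this assay, at which 1 of the 4 values shown sits.

As far as these compounds go, whether an amine or a carboxylic acid on this aromatic carbon would move the number beyond the scatter remains open. From the compounds shown here alone, it is also open whether the same swap would behave alike on compounds that carry a shorter chain in place of the butyl group.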